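Oxazole-amide series: 2-fluorophenyl for 4-acetylphenyl on ring nitrogen

The compounds below may be only part of what the source reports. "The series", "measured", "known", "first", "only" and "open" are said of these compounds alone.

Measured compounds:
compound 1, `Cc1nc(-c2cccc(F)c2)c(C(=O)N2CCN(c3cccc(Cl)c3)CC2)o1`, 33.7 nM
compound 2, `CC(=O)c1ccc(N2CCN(C(=O)c3oc(C)nc3-c3ccccc3)CC2)cc1`, "not active" (no number reported)

In a functional assay on HL-60 cells (Homo sapiens) for inhibition, read by MTT assay, with a stated time of 72 h (on this read-out lower numbers stand for stronger inhibition and higher numbers for weaker inhibition), compound 1 gives 33.7 nM, while compound 2 is reported as "not active" (no number reported), so no number stands for it; it can only be placed as weaker than compound 1 by an unknown margin. Compound 3, `Cc1nc(-c2ccccc2)c(C(=O)N2CCN(c3ccccc3F)CC2)o1`, differs from compound 2 by 2-fluorophenyl in place of 4-acetylphenyl on an amine nitrogen in a ring. Within the data shown here, the only active compound, compound 1, also carries a halogen-substituted phenyl on that ring nitrogen, whereas the inactive compound 2 carries 4-acetylphenyl there. The change is therefore expected to move compound 3 out of the inactive range into measurable inhibition, a large step toward stronger inhibition in this assay, though the phenyl on the oxazole of compound 3 lacks the fluorine present in compound 1. Compound 3 is estimated at 150 nM, between 20 nM and 2000 nM.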

Compound 3, half-maximal inhibitory concentration: 147 nM
For compound 3 the middle estimate is 1.0-fold (0.01 log units) above the measured one; the measured number falls inside the stated range.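

In this assay compound 3 gives 147 nM while compound 2 has no number, so no step can be read between compound 2 and compound 3. The compounds shown leave open the size of the change from 4-acetylphenyl to 2-fluorophenyl. No supporting evidence bears on this result.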